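From compound 2 to compound 3: one added group

The source may report more compounds than this note shows. Statements on the series, on what has been measured and on what is new or still open speak of the compounds shown alone.

In a functional assay on MCF7 cells (Homo sapiens) for antiproliferative activity, read by MTT assay, with a stated time of 48 h (on this read-out lower numbers stand for stronger inhibition and higher numbers for weaker inhibition), compound 1 (`CCN(CC)Cc1ccc2c(c1O)-c1ccc(cc1O)CCc1ccc(O)c(c1)Oc1ccc(cc1)CC2`) gives 7590 nM and compound 2 (`CN1CCN(Cc2ccc3c(c2O)-c2ccc(cc2O)CCc2ccc(O)c(c2)Oc2ccc(cc2)CC3)CC1`) gives 6020 nM. These two numbers cannot be told apart, so compound 2 stands level with compound 1. Compound 3 (`CN1CCN(Cc2cc3cc(c2O)Oc2ccc(cc2)CCc2ccc(CN4CCN(C)CC4)c(O)c2-c2ccc(cc2O)CC3)CC1`) keeps all of compound 2 and differs in one place: (4-methylpiperazin-1-yl)methyl in place of hydrogen on an aromatic carbon. Here (4-methylpiperazin-1-yl)methyl stands in place of hydrogen on an aromatic carbon, ortho to a hydroxy group. Within the data shown here, only one measured step offers any guidance: a 1.3-fold lower number from compound 1 to compound 2 (0.10 log units; within the scatter). That step exchanges one amine group for another, whereas the new change adds a group, so it is a loose guide and points in no clear direction. The expected change is a 1.2-fold lower number from compound 2 to compound 3 (0.08 log units; within the scatter), which means no shift beyond the scatter. In this assay the estimate for compound 3 is 5000 nM, with an expected range from 2000 nM to 13000 nM.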

Compound 3, half-maximal inhibitory concentration: 2890 nM
Estimate against measurement, compound 3: 1.7-fold (0.24 log units) above, within the range that was stated.
By their numbers in this assay, from the lowest: compound 3; then compounds 2 and 1 (each within the scatter of the next).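

In this assay, among these compounds, adding (4-methylpiperazin-1-yl)methyl on this aromatic carbon, ortho to a hydroxy group, brings a 2.1-fold lower number from compound 2 to compound 3 (0.32 log units; beyond the scatter) and this is the first step to go beyond the scatter. The earlier step only exchanged one amine group for another on a chain carbon and stayed within the scatter, so it said nothing about this aromatic carbon. This position can therefore carry a second (4-methylpiperazin-1-yl)methyl group with a modest gain rather than a loss, although no measurement at hand explains that gain.

As far as these compounds go, it remains open whether the gain depends on the piperazine ring or on any added group at this carbon. A morpholin-4-ylmethyl group or a plain methyl group here would help separate those two possibilities.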